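The source may report more compounds than this note shows. Statements on the series, on what has been measured and on what is new or still open speak of the compounds shown alone.

Compound 1 `Brc1ccc(Cn2cc(CCCOc3cccc4cccnc34)nn2)cc1` gives 28 ug/mL in a functional assay on MCF7 cells (Homo sapiens) for inhibition, read by sulforhodamine B assay, with a stated time of 48 h (a lower number here means a stronger inhibitor of growth, a higher number a weaker inhibitor of growth), the highest of the three numbers measured. Compound 2 `FC(F)(F)Oc1ccc(Cn2cc(CCCOc3cccc4cccnc34)nn2)cc1` gives 3.1 ug/mL and compound 3 `Fc1ccc(Cn2cc(CCCOc3cccc4cccnc34)nn2)cc1F` gives 21.3 ug/mL, so compound 1 sits furthest from compound 2 and closest to compound 3. Compound 4 `Clc1ccc(Br)cc1Cn1cc(CCCOc2cccc3cccnc23)nn1` is not yet measured; it differs from compound 1 in one place: 5-bromo-2-chlorophenyl in place of 4-bromophenyl on a saturated chain carbon bound to an aromatic nitrogen. The step that bears most on it is a 1.3-fold lower number from compound 1 to compound 3 (0.12 log units; within the scatter), a change of the same kind on the same saturated chain carbon. The larger step of a 9.0-fold lower number from compound 1 to compound 2 (0.96 log units; beyond the scatter) concerns a different substituent and offers no guide here. Compound 4 is therefore expected to move little, with an estimated step of a 1.4-fold lower number from compound 1 to compound 4 (0.15 log units; within the scatter), giving an expected value of 20 ug/mL with a range of 8 ug/mL to 50 ug/mL.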

Compound 4, concentration for 50% growth inhibition: 9.6 ug/mL
The estimate for compound 4 lay 2.1-fold (0.32 log units) above the measured number, within the range that was stated.
By their numbers in this assay, from the lowest: compound 2; then compound 4; then compounds 3 and 1 (each within the scatter of the next).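

In this assay the exchange of 4-bromophenyl for 5-bromo-2-chlorophenyl at this saturated chain carbon gives a 2.9-fold lower number from compound 1 to compound 4 (0.46 log units; beyond the scatter) and so shows that a change of the aryl group here can pass the scatter, which 3,4-difluorophenyl in compound 3 did not do. The same group also gives a 2.2-fold lower number from compound 3 to compound 4 (0.35 log units; beyond the scatter) and so separates these two halogen patterns. Nothing at hand explains the difference. Going by these compounds, compound 4 changes both the chlorine and the bromine place at once, so their separate shares remain open. On these data alone, how an amine or a carboxylic acid on this ring would read also remains open.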